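Lengthening an ester chain on a coumarin-type scaffold

The source may hold more compounds than are shown below. What is called first, only, known or untested is meant among the compounds shown, and "the series" means these compounds.

Compound 1 `CCC(=O)OCc1ccc2oc(=O)c(C(=O)Oc3cccc(Br)c3)cc2c1` and compound 2 `CCCCC(=O)OCc1ccc2oc(=O)c(C(=O)Oc3cccc(Br)c3)cc2c1` share a core and differ only in the ester chain. In a functional assay on HT-1080 cells (Homo sapiens), read by transwell migration, with a stated time of 24 h, tested at 0.1 uM (a higher number here means a weaker effect of the compound at the concentration tested, a lower number a stronger effect), compound 1 gives 84.4%, and compound 2 gives 92.4%. For the measured compounds named here, the one measured step, a number 8 percentage points higher from compound 1 to compound 2 (within the scatter), stays within the scatter, so the two compounds cannot be ordered. Compound 2 holds the higher of the two numbers, with compound 1 nearest, again within the scatter.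

Compound 3 `CCCCCCC(=O)OCc1ccc2oc(=O)c(C(=O)Oc3cccc(Br)c3)cc2c1` extends the same chain once more: ethyl in place of hydrogen on a saturated chain carbon, four bonds along the chain from a carbonyl carbon. Going by the values given here, the only step that bears on this change is the earlier lengthening, which showed no effect beyond the scatter. The expected step for compound 3 is a number 0.4 percentage points lower from compound 2 to compound 3 (within the scatter), none beyond the scatter, because a number 8 percentage points higher from compound 1 to compound 2 (within the scatter) was itself within it. Compound 3 is therefore expected to give 92%, in a range from 80% to 102%.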

Compound 3, a percentage reported as activity, at one concentration (the size of the read-out at that concentration, not a potency): 89.4%
Beside the measured number, compound 3's estimate is 2.6 percentage points above it; low and high end bracket the measured number.
By their numbers in this assay, from the lowest: compounds 1, 3 and 2 (each within the scatter of the next).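

In this assay, adding ethyl in place of hydrogen on a saturated chain carbon, four bonds along the chain from a carbonyl carbon, gives the step of a number 3 percentage points lower from compound 2 to compound 3 (within the scatter) and, taken across the whole lengthening, the step of a number 5 percentage points higher from compound 1 to compound 3 (within the scatter) as well. With these two steps added to the earlier one, all three ester chains now sit within the scatter of one another, so compounds 1, 2 and 3 cannot be ordered, and this position shows no response to chain length across these three compounds. No separate measurement is available that could explain this result.

Still open, on these data alone, is whether a branched chain, a much longer chain, or a chain ending in an amine or a carboxylic acid would move the number beyond the scatter. A read-out at a single concentration also leaves the potency of all three compounds unknown.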